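Chloro substitution on the aryl thioether hydroxamate series

This account rests on a few compounds, and the source may have more. Where it says the series, first, only, none or still open, it means among the compounds named here.

Compound 1 `O=C(CCCCC[S+]([O-])c1ccccc1)NO` and compound 3 `O=C(CCCCC[S+]([O-])c1ccc(Cl)cc1)NO` share a core and are both measured in a functional assay on CCRF-CEM cells (Homo sapiens) for inhibition; a higher number here means a weaker inhibitor, a lower number a stronger inhibitor. In this assay compound 1 gives only a limit, > 25000 nM, and no number. Compound 3 gives 2600 nM in this assay. The change between them is chloro in place of hydrogen on an aromatic carbon, and the step is an at least 9.6-fold lower number from compound 1 to compound 3 (0.98 log units; beyond the scatter). The step can be given only as a bound due to the limit of > 25000 nM in this assay, at which 1 of the 3 values shown sits, so its true size is open upward.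

Compound 2 `O=C(/C=C/C=C/CSc1ccccc1)NO` belongs to the same family, but in this assay compound 2 has "not determined" (no result reported). How the core of compound 2 differs from the core of compound 1 is not broken down here.

Compound 4 `O=C(/C=C/C=C/CSc1ccc(Cl)cc1)NO` is not yet measured. It differs from compound 2 by chloro in place of hydrogen on an aromatic carbon, the same change, at a place described in the same words, as made from compound 1 to compound 3. With no number for compound 2, the expectation for compound 4 in this assay cannot be set by a step from compound 2 and rests only on the level reached by compound 3, 2600 nM, after the same change. On that basis compound 4 is estimated at 2500 nM in this assay, within an expected range of 400 nM to 15000 nM.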

Compound 4, half-maximal inhibitory concentration: 1600 nM
Beside the measured number, compound 4's estimate is 1.6-fold (0.19 log units) above it; measured number inside the range.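

Among the compounds shown here, no step from compound 2 to compound 4 can be read in this assay, where compound 2 has "not determined" (no result reported) and compound 4 gives 1600 nM. Still open is whether chloro in place of hydrogen shifts the number by a similar amount on the core of compound 2 and the core of compound 1, as the step from compound 1 to compound 3 remains open upward due to a limit: the limit of > 25000 nM in this assay, at which 1 of the 4 values shown sits.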